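A Shorter Acid Chain on the Shared Core

The source may report more compounds than this note shows. Statements on the series, on what has been measured and on what is new or still open speak of the compounds shown alone.

Among the compounds with values here, in an ADME assay on the whole organism (Mus musculus, strain CD1) for pharmacokinetics, read by LC-MS, with a stated time of 24 h, at a dose of 1 mg/kg by the intravenous route (on this read-out higher numbers stand for wider distribution into tissues and lower numbers for narrower distribution), compound 1 `O=C(O)Cc1nn(Cc2cn3cc(OCC4CC4)c(Cl)cc3n2)c2ccccc2c1=O` gives 0.79 L/kg and compound 2 `CCC(C(=O)O)c1nn(Cc2cn3cc(OCC4CC4)c(Cl)cc3n2)c2ccccc2c1=O` gives 0.78 L/kg, so compound 2 stands level with the only other measured compound. Compound 3 `C[C@H](C(=O)O)c1nn(Cc2cn3cc(OCC4CC4)c(Cl)cc3n2)c2ccccc2c1=O` differs from compound 2 by having 1-carboxyethyl in place of 1-carboxypropyl on an aromatic carbon. Within the data shown here, the one measured step bearing on this change, a 1.0-fold lower number from compound 1 to compound 2 (0.01 log units; within the scatter), put ethyl in place of hydrogen on the chain and stayed within the scatter. No shift beyond the scatter is therefore expected in this assay. The expected step is a 1.0-fold higher number from compound 2 to compound 3 (0.01 log units; within the scatter). For compound 3 the estimate is 0.8 L/kg, with an expected range of 0.45 L/kg to 1.4 L/kg.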

Compound 3, volume of distribution at steady state: 0.56 L/kg
Compound 3: middle estimate off by 1.4-fold (0.15 log units), on the high side, within the range that was stated.
By their numbers in this assay, from the lowest: compounds 3, 2 and 1 (each within the scatter of the next).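

In this assay, 1-carboxyethyl in place of 1-carboxypropyl gives (a 1.4-fold lower number from compound 2 to compound 3 (0.14 log units; within the scatter)), and methyl in place of hydrogen on the chain carbon gives (a 1.4-fold lower number from compound 1 to compound 3 (0.15 log units; within the scatter)). Hydrogen, methyl and ethyl on this carbon therefore all stay within the scatter of one another, even with the defined stereocentre that only compound 3 carries. Nothing available accounts for these small steps. Still open, going by these compounds, are the mirror-image form of compound 3 and whether an amine or a phenyl ring on this chain carbon would move the number beyond the scatter.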